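A few compounds are considered here, and "the series" means these few. Any claim that something is new, unique, unknown or untested is made for them only; others in the source may bear on it.

Measured in a functional assay on KB 3-1 cells (Homo sapiens) for cytotoxicity, read by MTT assay, with a stated time of 72 h; a lower number here means a stronger inhibitor, a higher number a weaker inhibitor:
- compound 1 `O=C1Nc2ccccc2/C1=N/NC(=S)Nc1ccccc1`: 3530 nM
- compound 2 `O=C1Nc2ccccc2/C1=N/NC(=S)Nc1cccnc1`: > 50000 nM, a limit of the assay
- compound 3 `COc1ccccc1NC(=S)N/N=C1\C(=O)Nc2ccccc21`: 4960 nM

Within the data shown here, only two of these readings are true numbers, and they lie together: the step between them is a 1.4-fold higher number from compound 1 to compound 3 (0.15 log units; within the scatter). Among the measured compounds shown here, compound 1 therefore stands level with its one numeric neighbour, while the third reading is only a limit.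

Next in the series is compound 4 `CCc1ccc(NC(=S)N/N=C2\C(=O)Nc3ccccc32)cc1`, not yet measured. Its difference from compound 1 is ethyl in place of hydrogen on an aromatic carbon, para to a large group.

For the measured compounds named here, two measured steps bear on this change. The closer guide is the methoxy step to compound 3, a 1.4-fold higher number from compound 1 to compound 3 (0.15 log units; within the scatter), since it too replaces hydrogen on an aromatic carbon and keeps the phenyl. The other is an at least 14-fold higher number from compound 1 to compound 2 (1.15 log units; beyond the scatter), which is large but swaps the phenyl itself, a change compound 4 does not make, so it carries little weight here. On these data alone, one substituent step is thin evidence, and the ethyl group itself is untested, so the range is kept wide.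

No shift beyond the scatter is expected in this assay. The expected step is a 1.2-fold lower number from compound 1 to compound 4 (0.07 log units; within the scatter). For compound 4 the estimated value is 3000 nM, with an expected range from 1000 nM to 9000 nM.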

Compound 4, half-maximal inhibitory concentration: 4050 nM
Beside the measured number, compound 4's estimate is 1.4-fold (0.13 log units) below it; the range from low to high includes it.
By their numbers in this assay, from the lowest: compounds 1, 4 and 3 (each within the scatter of the next). At a limit, above all of these: compound 2.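

In this assay, ethyl in place of hydrogen on an aromatic carbon, para to a large group, gives a 1.1-fold higher number from compound 1 to compound 4 (0.06 log units; within the scatter) and so leaves the reading level with that of the parent. The only earlier substituent on this phenyl was methoxy, with a 1.4-fold higher number from compound 1 to compound 3 (0.15 log units; within the scatter) in the same assay; the ethyl result now adds a group of carbon only, with no hydrogen-bond donor or acceptor, at a position para to a large group, and again no shift beyond the scatter appears. The data shown offer no measured property that bears on this flat step.

Still open, on these data alone, is whether the position stays this flat with a longer chain such as butyl, or with an amine or a carboxylic acid in place of ethyl, as the two substituents read so far both leave the number within the scatter of compound 1. Among these compounds, compound 2, the one change to the phenyl itself, reads > 50000 nM, which is a limit and not a number, so how far that ring can be altered without such a loss also remains unsettled.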